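Methyl for methoxy on the aryl ether of compound 1

This account rests on a few compounds, and the source may have more. Where it says the series, first, only, none or still open, it means among the compounds named here.

Of the compounds shown here, three sharing one core have been measured in a functional assay on cells for inhibition, with Murine T-cell line (Mus musculus) as the target; a lower number here means a stronger inhibitor, a higher number a weaker inhibitor. Compound 1 `CC[C@@H]1/C=C(\C)C[C@H](C)C[C@H](OC)[C@H]2O[C@@](O)(C(=O)C(=O)N3CCCC[C@H]3C(=O)O[C@H](/C(C)=C/[C@@H]3CC[C@@H](Oc4cccc(OC)c4)[C@H](OC)C3)[C@H](C)[C@@H](O)CC1=O)[C@H](C)C[C@@H]2OC` gives 3.4 nM and stands second highest of the three numbers. Compound 2 `CC[C@@H]1/C=C(\C)C[C@H](C)C[C@H](OC)[C@H]2O[C@@](O)(C(=O)C(=O)N3CCCC[C@H]3C(=O)O[C@H](/C(C)=C/[C@@H]3CC[C@@H](Oc4ccc(OC)cc4)[C@H](O)C3)[C@H](C)[C@@H](O)CC1=O)[C@H](C)C[C@@H]2OC` gives 1.2 nM, the nearest number to that of compound 1, a gap beyond the scatter. Compound 3 `CC[C@@H]1/C=C(\C)C[C@H](C)C[C@H](OC)[C@H]2O[C@@](O)(C(=O)C(=O)N3CCCC[C@H]3C(=O)O[C@H](/C(C)=C/[C@@H]3CC[C@@H](Oc4cc(C(F)(F)F)cc(C(F)(F)F)c4)[C@H](OC)C3)[C@H](C)[C@@H](O)CC1=O)[C@H](C)C[C@@H]2OC` is the furthest, giving 607 nM, far beyond the scatter.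

The account now follows a single change on compound 1 that yields compound 4 `CC[C@@H]1/C=C(\C)C[C@H](C)C[C@H](OC)[C@H]2O[C@@](O)(C(=O)C(=O)N3CCCC[C@H]3C(=O)O[C@H](/C(C)=C/[C@@H]3CC[C@@H](Oc4cccc(C)c4)[C@H](OC)C3)[C@H](C)[C@@H](O)CC1=O)[C@H](C)C[C@@H]2OC`: methyl in place of methoxy on an aromatic carbon. The group that leaves and the group that enters are both small and uncharged, and the site is the same aromatic carbon, meta to a large group, so the shared core and the aryl ether are otherwise untouched. Going by the values given here, nothing among the measured compounds isolates this exact exchange, and the large loss seen for compound 3 involves a quite different substitution pattern.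

Compound 4 is therefore expected to remain close to compound 1, with a step from compound 1 to compound 4 of a 1.5-fold higher number from compound 1 to compound 4 (0.17 log units; within the scatter) that may not exceed the scatter. The estimate for compound 4 in this assay is 5 nM, within a range of 1.5 nM to 16 nM.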

Compound 4, half-maximal inhibitory concentration: 5.4 nM
For compound 4 the middle estimate is 1.1-fold (0.03 log units) below the measured one; measured number inside the range.
By their numbers in this assay, from the lowest: compound 2; then compounds 1 and 4 (each within the scatter of the next); then compound 3.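

Going by these compounds alone, exchanging 3-methoxyphenoxy for 3-methylphenoxy on the shared core gives the first single-place step: in this assay it is a 1.6-fold higher number from compound 1 to compound 4 (0.20 log units; within the scatter) and so does not stand clear of the scatter. Within the data shown here, at this aromatic carbon, then, the methoxy group and its one hydrogen-bond acceptor can give way to a methyl group with no reliable change in this read-out, which the earlier compounds, each differing from compound 1 in more than a single place, could not show. No measurement at hand explains why the two groups read alike.

Going by these compounds, whether an amine or a carboxylic acid on this same aromatic carbon would also leave the number in this assay within the scatter of compound 1 stays open. So does the effect of a plain hydrogen there, which would show whether this carbon needs any substituent at all.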